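Fluoro in Place of Methoxy: Toward Compound 3

The source may report more compounds than this note shows. Statements on the series, on what has been measured and on what is new or still open speak of the compounds shown alone.

Of the compounds shown here, two have been tested in a functional assay on MOLT-4 cells (Homo sapiens) for inhibition, read by sulforhodamine B assay, with a stated time of 48 h; on this read-out lower numbers stand for higher toxicity in this test and higher numbers for lower toxicity in this test. Compound 1 `CCOC(=O)[C@H](CCC(=O)O)NC(=O)c1ccc(Oc2nc3cc(N)cc(N)c3nc2-c2ccccc2)cc1` gives < 100000 nM, which is a limit of the assay, not a number. Compound 2 `COc1ccc(Sc2nc3cc(N)cc(N)c3nc2-c2ccccc2)cc1` likewise gives only a limit, < 100000 nM. Compound 2 therefore sits at the limit of < 100000 nM in this assay, at which 2 of the 2 values shown sit, with no numeric anchor. Compound 3 `Nc1cc(N)c2nc(-c3ccccc3)c(Sc3ccc(F)cc3)nc2c1` differs from compound 2 by fluoro in place of methoxy on an aromatic carbon. Among the measured compounds shown here, with no measured step to guide it, the change is expected to stay within the scatter, a step that the limit leaves unreadable from compound 2 to compound 3. Compound 3 is estimated at 30000 nM, between 5000 nM and 100000 nM, with a fair chance that again only a limit is reported.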

Compound 3, concentration lethal to 50% of the cells: < 100000 nM
Compound 3 gave a limit, no number (the forecaster's own chance of this, stated with the estimate: 70%); the middle value lies beyond the limit too.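

No step can be read from compound 2 to compound 3, because each gives only a limit, not a number: the limit of < 100000 nM in this assay, at which 3 of the 3 values shown sit.

From the compounds shown here alone, whether fluoro in place of methoxy changes the read-out at all, and how the three compounds rank, stays open.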